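Bromobenzylidene pair on a shared diketopiperazine-like core

The source may report more compounds than this note shows. Statements on the series, on what has been measured and on what is new or still open speak of the compounds shown alone.

Working notes on the series. Two compounds carry numbers or outcomes in a functional assay on HeLa cells (Homo sapiens) for cytotoxicity, read by CCK-8 assay, with a stated time of 72 h; on this read-out higher numbers stand for weaker inhibition and lower numbers for stronger inhibition. Compound 1 `C=CCn1c(=O)/c(=C\c2ccc(F)c(Br)c2)[nH]c(=O)/c1=C\c1ccccc1OC` is reported in this assay as "not active" (no number reported), with no number attached. For the measured compounds named here, compound 2 `C=CCn1c(=O)/c(=C\c2cccc(Br)c2)[nH]c(=O)/c1=C\c1ccccc1OC` gives 5400 nM in this assay, and it is the only compound in the set for which a number stands at all, so there is no measured step against which to calibrate the change that follows.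

Compound 3 `C=CCn1c(=O)/c(=C\c2cccc(Br)c2)[nH]c(=O)/c1=C\c1cccc(Br)c1` differs from compound 2 in one place: 3-bromophenyl in place of 2-methoxyphenyl on a double-bonded chain carbon bound to an aromatic carbon. The two arms of the shared core thus become identical in compound 3. Going by the values given here, nothing among the measured compounds shows what removing the 2-methoxyphenyl does, and the outcome for compound 1 shows only that a different aryl pattern on the other arm can take the read-out out of the measurable range.

The expected step from compound 2 to compound 3 in this assay is a 1.2-fold lower number from compound 2 to compound 3 (0.08 log units; within the scatter), which is judged as no change beyond the scatter. Compound 3 is estimated at 4500 nM in this assay, with a range from 1500 nM to 15000 nM.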

Compound 3, half-maximal inhibitory concentration: "not active" (no number reported)
Compound 3: no number reported, so the estimate cannot be set against anything.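

For the compounds shown here, compound 3 is reported in this assay as "not active" (no number reported), so no step from compound 2 to compound 3 can be read. Nothing shown bears on this outcome. The compounds shown leave open which features of the two aryl arms on the shared core decide whether a number can be read at all.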